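Thiophene to Phenyl: Expected Cytotoxicity of Compound 3

A few compounds are considered here, and "the series" means these few. Any claim that something is new, unique, unknown or untested is made for them only; others in the source may bear on it.

Measured compounds:
Compound 1, `Oc1cccc(-c2cc(-c3ccc(Cl)cc3)nc(-c3cccs3)c2)c1`; in a functional assay on DU-145 cells (Homo sapiens) for cytotoxicity, read by CCK-8 assay and cell counting, with a stated time of 2 days (on this read-out lower numbers stand for stronger inhibition and higher numbers for weaker inhibition), compound 1 gives 11600 nM.
Compound 2, `Oc1cccc(-c2cc(-c3ccc(Cl)cc3)nc(-c3ccsc3)c2)c1`; in this assay compound 2 gives 11600 nM.

Compound 2 stands level with compound 1 at the digits shown; its nearest neighbour is compound 1, and the only measured step, no change at the digits printed from compound 1 to compound 2 (within the scatter), is no change within the scatter. That step exchanged one attachment point of the same five-membered sulfur ring for another, and the cells responded alike.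

Compound 3, `Oc1cccc(-c2cc(-c3ccccc3)nc(-c3ccc(Cl)cc3)c2)c1`, differs from compound 2 by phenyl in place of thiophen-3-yl on an aromatic carbon. Among the measured compounds shown here, this is a larger structural change than the measured one: the sulfur ring is replaced by a plain six-carbon ring, and no measured pair shows what such a replacement does here. For the measured compounds named here, the one step that bears on it, from compound 1 to compound 2, was flat, which suggests that this position tolerates variation without a shift beyond the scatter.

The step from compound 2 to compound 3 in this assay is therefore expected to be a 1.0-fold higher number from compound 2 to compound 3 (0.01 log units; within the scatter), no change beyond the scatter in either direction. Compound 3 is estimated at 12000 nM, with a range from 4000 nM to 36000 nM.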

Compound 3, half-maximal inhibitory concentration: 11200 nM
The estimate for compound 3 lay 1.1-fold (0.03 log units) above the measured number; the measured number falls inside the stated range.
By their numbers in this assay, from the lowest: compounds 3, 1 and 2 (each within the scatter of the next).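

In this assay, replacing the five-membered sulfur ring with phenyl on the aromatic carbon next to the ring nitrogen gives a 1.0-fold lower number from compound 2 to compound 3 (0.02 log units; within the scatter), and the same kind of exchange starting from the other thiophene gives a 1.0-fold lower number from compound 1 to compound 3 (0.02 log units; within the scatter). The earlier pair showed only that moving the attachment point of the thiophene made no difference beyond the scatter, whereas these steps show that a six-membered ring of carbon only, without the sulfur, also reads the same in this assay. No supporting measurement is available to explain why the three compounds read alike.

Thiophen-2-yl, thiophen-3-yl and phenyl are all aromatic rings with no net charge, so it remains open whether the same flat reading would hold for a quite different group at this carbon, such as an amine, a carboxylic acid or a longer alkyl chain. On these data alone, all three compounds also keep the 3-hydroxyphenyl and 4-chlorophenyl groups, so it is equally open whether this tolerance would persist if either of those groups were changed.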